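Thiophen-2-yl for phenyl: from compound 1 to compound 3

A few compounds are considered here, and "the series" means these few. Any claim that something is new, unique, unknown or untested is made for them only; others in the source may bear on it.

Of the compounds shown here, two carry numbers so far. Compound 1 `COc1cc(/C=C/C(=O)/C=C/c2ccccc2)ccc1OCc1cn(CCCOc2cc(=O)oc3ccccc23)nn1` and compound 2 `COc1cccc(/C=C/C(=O)/C=C/c2ccc(OCc3cn(CCCCOc4cc(=O)oc5ccccc45)nn3)c(OC)c2)c1` were both tested in a functional assay on HCT-116 cells (Homo sapiens) for inhibition, read by sulforhodamine B assay, with a stated time of 48 h, tested at 50 uM; on this read-out higher numbers stand for more inhibition of growth at the one concentration tested and lower numbers for less inhibition of growth; compound 1 gives 45% and compound 2 gives 44%. Compound 1 stands highest of the two numbers, but the gap to compound 2 lies within the scatter, so the two cannot be told apart on this read-out. Among the measured compounds shown here, no step between measured compounds that differ in a single place has been recorded, so there is nothing to calibrate a change of the kind made next.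

Compound 3 `COc1cc(/C=C/C(=O)/C=C/c2cccs2)ccc1OCc1cn(CCCOc2cc(=O)oc3ccccc23)nn1` differs from compound 1 in one place: thiophen-2-yl in place of phenyl on a double-bonded chain carbon bound to a double-bonded chain carbon. The measured pair gives no guide to this exchange, so no movement beyond the scatter is expected. The step of a number 2 percentage points lower from compound 1 to compound 3 (within the scatter) is expected to stay small and undirected. Compound 3 is estimated at 43%, within a range from 28% to 58%.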

Compound 3, percent growth inhibition at one concentration: 58%
Compound 3: middle estimate off by 15 percentage points, on the low side; low and high end bracket the measured number.
By their numbers in this assay, from the lowest: compounds 2 and 1 (each within the scatter of the next); then compound 3.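

In this assay, among the compounds shown here, thiophen-2-yl in place of phenyl on a double-bonded chain carbon bound to a double-bonded chain carbon gives a number 13 percentage points higher from compound 1 to compound 3 (beyond the scatter) and so provides the first single-place step, one that lies beyond the scatter. This place therefore responds to an exchange of one aromatic ring for another, which compound 1 and compound 2, differing in more than one place, could not show. Nothing at hand explains the step, and this single pair sets no trend for the position.

On these data alone, whether the exchange gives a similar step on the core of compound 2 remains open. Also open, as far as these compounds go, is how this place responds to furan-2-yl, thiophen-3-yl or a phenyl carrying an amine or a carboxylic acid.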